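A few compounds are considered here, and "the series" means these few. Any claim that something is new, unique, unknown or untested is made for them only; others in the source may bear on it.

For the measured compounds named here, in a functional assay on HT-29 cells (Homo sapiens) for inhibition, read by MTT assay, with a stated time of 72 h (a higher number here means a weaker inhibitor, a lower number a stronger inhibitor), compound 1 (`O=C1CS/C(=N\c2nc3cc(-c4ccc(Cl)cc4)[se]c3s2)N1`) gives 42400 nM, the only true number so far. Compound 2 (`CN(C)c1ccc(/C=C2/S/C(=N\c3nc4cc(-c5ccc(Cl)cc5)sc4s3)NC2=O)cc1`) gives > 50000 nM, which is a limit. Compound 3 (`O=C1N/C(=N/c2nc3cc(-c4ccc(Cl)cc4)sc3s2)S/C1=C/c1ccc2ccccc2c1`) gives > 50000 nM, also a limit, and so it stands at the limit of > 50000 nM in this assay, at which 2 of the 3 values shown sit. Compound 4 (`O=C1N/C(=N/c2nc3cc(-c4ccc(Cl)cc4)sc3s2)S/C1=C/c1ccc(F)cc1`) carries one change from compound 3: 4-fluorophenyl in place of naphthalen-2-yl, on a double-bonded chain carbon bound to a double-bonded ring carbon (4-fluorophenyl in place of naphthalen-2-yl on a double-bonded chain carbon bound to a double-bonded ring carbon). Going by the values given here, no size can be carried over because a step that the two limits leave unreadable from compound 2 to compound 3 is the only measured step at this place. The expected change is an at least 1.1-fold lower number from compound 3 to compound 4 (0.04 log units; that floor lies within the scatter), with no direction favoured, and another limit is likely. For compound 4 the estimated value is 45000 nM, with an expected range from 15000 nM to 80000 nM.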

Compound 4, half-maximal inhibitory concentration: > 50000 nM
Compound 4: only a limit was reported; the forecaster's own chance of this, stated with the estimate: 60%; middle value at least 1.1-fold (0.04 log units) from the limit.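

Compound 4 also gives only a limit, so the steps linking compound 2, compound 3 and compound 4 cannot be read: the limit of > 50000 nM in this assay, at which 3 of the 4 values shown sit.

On these data alone, how far apart these three truly lie in this assay stays open.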